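The source may hold more compounds than are shown below. What is called first, only, known or untested is meant among the compounds shown, and "the series" means these compounds.

Compound 1 `C=CCn1c(SCC(=O)Nc2ccc(/C(C)=N/O)cc2)nnc1-c1ccc(OC)cc1` and compound 2 `C=CCn1c(SCC(=O)Nc2ccc(C(C)=O)cc2)nnc1-c1ccc(OC)cc1` share one core; compound 3 `CCn1c(SCC(=O)Nc2ccc(/C(C)=N/O)cc2)nnc1-c1ccccc1` and compound 4 `CCn1c(SCC(=O)Nc2ccc(C(C)=O)cc2)nnc1-c1ccccc1` share another, and the difference between the two cores is not broken down here. In a functional assay on the whole organism (strain albino) for inhibition, with Rattus norvegicus as the target, read by paw edema, with stated times of 30 min and 2 h, at a dose of 0.28 mmol/kg by the oral route (on this read-out lower numbers stand for less inhibition and higher numbers for more inhibition at the one dose given (going by the name of the read-out)), compound 1 gives 59%, compound 2 gives 51% and compound 3 gives 57%. The change from compound 1 to compound 2, (a group of 3 heavy atoms (2 carbon, 1 oxygen; no ring) in place of a group of 4 heavy atoms (2 carbon, 1 nitrogen, 1 oxygen; no ring), on an aromatic carbon), made a step of a number 8 percentage points lower from compound 1 to compound 2 (within the scatter). The same change is made from compound 3 to compound 4, (a group of 3 heavy atoms (2 carbon, 1 oxygen; no ring) in place of a group of 4 heavy atoms (2 carbon, 1 nitrogen, 1 oxygen; no ring), on an aromatic carbon), at a place described in the same words. Going by the values given here, compound 4 is expected to move by a number 8 percentage points lower from compound 3 to compound 4 (within the scatter) in this assay, because the one measured instance of this change gave a number 8 percentage points lower from compound 1 to compound 2 (within the scatter). Compound 4 is therefore estimated at 49%, with an expected range of 39% to 59%. The estimate rests on a single measured pair.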

Compound 4, a percentage reported as inhibition, in the whole organism at one dose (the size of the read-out at that dose, not a potency): 53%
Estimate against measurement, compound 4: 4 percentage points below, and the stated range covers the measured number.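

In this assay, acetyl in place of the group of 4 heavy atoms on the aromatic carbon gives a number 4 percentage points lower from compound 3 to compound 4 (within the scatter). Set beside the earlier step, the change carries from one core to the other without a difference that can be told from the scatter: the same change on two cores in this assay, a number 8 percentage points lower (within the scatter) from compound 1 to compound 2 and a number 4 percentage points lower (within the scatter) from compound 3 to compound 4, 4 percentage points apart, within the scatter of two such steps. Each step also lies within the scatter, so the pair does not show that the change itself alters inhibition at this one dose, and two cores do not establish that it would carry to others.

Still open, going by these compounds, is whether another group at this place, such as an amine or a carboxylic acid, would give a step beyond the scatter. The difference between the two cores also remains unresolved.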